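The source may report more compounds than this note shows. Statements on the series, on what has been measured and on what is new or still open speak of the compounds shown alone.

In a functional assay on KB cells (Homo sapiens) for cytotoxicity (a higher number here means a weaker inhibitor, a lower number a stronger inhibitor), compound 1 (`Cc1ccc(S(=O)(=O)Oc2cccc3c2C(=O)C=CC3=O)cc1`) gives 10700 nM and compound 2 (`CCCCOC1=CC(=O)c2ccccc2C1=O`) gives 27000 nM. Compound 2 thus has the higher of the two numbers, which makes it the weaker inhibitor of the pair by a gap beyond the usual scatter. The two compounds differ in more than one place, so this gap cannot be tied to any single group. Compound 3 (`CS(=O)(=O)OC1=CC(=O)c2ccccc2C1=O`) has methylsulfonyl in place of butyl on an oxygen on an unsaturated carbon. Within the data shown here, compound 1 also carries a sulfonyl group on an oxygen, and its 10700 nM is the only guide available, a thin one. A moderate move toward a lower number, beyond the scatter, is therefore expected, estimated as a 4.5-fold lower number from compound 2 to compound 3 (0.65 log units; beyond the scatter). In this assay, the expected value for compound 3 is 6000 nM, with an estimated range of 1500 nM to 25000 nM.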

Compound 3, half-maximal inhibitory concentration: 7180 nM
Compound 3: the middle estimate sits 1.2-fold (0.08 log units) below what was measured, within the range that was stated.
By their numbers in this assay, from the lowest: compounds 3 and 1 (each within the scatter of the next); then compound 2.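

In this assay, among these compounds, a 3.8-fold lower number from compound 2 to compound 3 (0.58 log units; beyond the scatter) is the first step here that can be tied to a single place: the oxygen on the unsaturated carbon. Butyl and methylsulfonyl have the same heavy-atom count, but one is all carbon and the other carries sulfur and oxygen, so the number responds to the kind of group on this oxygen and not only to its atom count. The butyl chain is also not needed to reach a number in this range, and no measurement shown here explains why the number moved.

One step cannot show whether the whole methylsulfonyl group matters or only some part of it. On these data alone, it also remains open whether a methyl or acetyl group on this oxygen, or an amine in place of the oxygen, would give a number closer to compound 2 or compound 3.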